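The source may hold more compounds than are shown below. What is called first, only, known or untested is meant among the compounds shown, and "the series" means these compounds.

Compound 1 `COc1cc(NC(C)CCCNC(=O)NCCCO)c2ncccc2c1`: "not determined" (no result reported)
Compound 2 `COc1cc(NC(C)CCCNC(=O)NNC(=O)/C=C/c2ccccc2F)c2ncccc2c1`: 25100 nM
Compound 3 `COc1cc(NC(C)CCCNC(=O)NNC(=O)Nc2cccc(Cl)c2)c2ncccc2c1`: 58600 nM

These results come from an ADME assay on L6 cells (Rattus norvegicus) for cytotoxicity, read by resazurin assay, with a stated time of 70 h; on this read-out higher numbers stand for weaker inhibition and lower numbers for stronger inhibition. Going by the values given here, only two of the compounds have a number, and compound 3, at 58600 nM, holds the higher of the two. Compound 4 `COc1cc(NC(C)CCCNC(=O)NNC(=O)Nc2ccc(Cl)cc2)c2ncccc2c1` has not yet been measured. It has the same atoms as compound 3, joined differently, with 4-chlorophenyl in place of 3-chlorophenyl on an amide-type nitrogen.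

Just one measured step is available, a 2.3-fold higher number from compound 2 to compound 3 (0.37 log units; beyond the scatter), and it is modest. Among the compounds with values here, that step exchanged one whole group for another, so it does not directly test a change of this kind, and no measured pair does. Even so, it sets a rough scale, and for this smaller change no step beyond the usual scatter is expected, in either direction. The estimated step is a 1.2-fold lower number from compound 3 to compound 4 (0.07 log units; within the scatter). In this assay, the estimate for compound 4 is 50000 nM, with an expected range of 25000 nM to 100000 nM.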

Compound 4, half-maximal inhibitory concentration: 91900 nM
Compound 4: the middle estimate sits 1.8-fold (0.26 log units) below what was measured; low and high end bracket the measured number.
By their numbers in this assay, from the lowest: compound 2; then compounds 3 and 4 (each within the scatter of the next).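

Moving the chlorine from 3-chlorophenyl to 4-chlorophenyl on the amide-type nitrogen gives a 1.6-fold higher number from compound 3 to compound 4 (0.20 log units; within the scatter) in this assay, so this first test of the chlorine's place shows no change that stands out from the scatter of repeated measurements. Replacing the whole 2-(2-fluorophenyl)ethenyl group on the carbonyl carbon with (4-chlorophenyl)amino gives a 3.7-fold higher number from compound 2 to compound 4 (0.56 log units; beyond the scatter), a modest step that lies beyond that scatter. No available evidence accounts for either step.

The compounds shown leave open whether a phenyl ring with no chlorine, or a 4-methoxyphenyl group, would fit with these two chlorophenyl compounds. Going by these compounds, it also remains open whether an amine or a carboxylic acid on this ring would give a larger step than moving the chlorine does.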